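Acyl group on the ring amide nitrogen: microsomal half-life

The compounds below may be only part of what the source reports. "The series", "measured", "known", "first", "only" and "open" are said of these compounds alone.

Compound 1 `CC(C)(C)c1cc(NC(=O)[C@@H]2CCCCN2C(=O)C2CCCCC2)no1` gives 0.483 h in an ADME assay (liver) for metabolic stability, with Liver microsome (Homo sapiens) as the target, read by LC-MS, using microsomes and NADPH, tested at 1 uM; a lower number here means that the compound disappears faster, a higher number that the compound lasts longer.
Compound 2 `CC(C)(C)c1cc(NC(=O)[C@@H]2CCCCN2C(=O)N2CCCCC2)no1` gives 0.233 h in this assay.
Compound 3 `CC(C)(C)c1cc(NC(=O)[C@@H]2CCCCN2C(=O)N2CCOCC2)no1` gives only a limit, > 2 h, in this assay.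

Compound 3 thus sits at the upper boundary of what this assay reports, with no number beyond the limit (the limit of > 2 h in this assay, at which 1 of the 3 values shown sits). The next change is 4-propanoylpiperazin-1-yl in place of morpholin-4-yl on a carbonyl carbon, giving compound 4 `CCC(=O)N1CCN(C(=O)N2CCCC[C@H]2C(=O)Nc2cc(C(C)(C)C)on2)CC1`. The steps into the morpholine compound are the relevant ones: an at least 4.1-fold higher number from compound 1 to compound 3 (0.61 log units; beyond the scatter) and an at least 8.5-fold higher number from compound 2 to compound 3 (0.93 log units; beyond the scatter), both rising; the earlier 2.1-fold lower number from compound 1 to compound 2 (0.32 log units; beyond the scatter) went the other way. Going by the values given here, no measured step covers the entering group itself. Compound 4 is therefore expected to stay in the region of compound 3, with a number no higher from compound 3 to compound 4 (the limit leaves the size open) within the scatter. The estimate for compound 4 is 2 h, in the range 0.8 h to 4 h, with a fair chance that only a limit is again reported.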

Compound 4, half-life: > 2 h
Compound 4 was reported as a limit; the forecaster's own chance of this, stated with the estimate: 50%; the middle value sits exactly at the limit.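

In this assay, compound 4 also gives only a limit, > 2 h, so 4-propanoylpiperazin-1-yl on this carbonyl carbon leaves the half-life at the upper boundary already reached with morpholin-4-yl: the limit of > 2 h in this assay, at which 2 of the 4 values shown sit.

The gain over piperidin-1-yl and cyclohexyl persists with this larger group: an at least 8.5-fold higher number from compound 2 to compound 4 (0.93 log units; beyond the scatter) and an at least 4.1-fold higher number from compound 1 to compound 4 (0.61 log units; beyond the scatter). The step from compound 3 to compound 4 cannot be read, since both values are limits.

On these data alone, how far either compound lies beyond the limit remains open. Also open, as far as these compounds go, is whether an unsubstituted piperazine amine, or a longer acyl chain in place of propanoyl, would hold the half-life there.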